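Chain Extension on the Amide Side Chain of Compound 3

The source may report more compounds than this note shows. Statements on the series, on what has been measured and on what is new or still open speak of the compounds shown alone.

In a functional assay on NCI-H1975 cells (Homo sapiens) for antiproliferative activity, read by CCK-8 assay, with a stated time of 72 h (a lower number here means a stronger inhibitor of growth, a higher number a weaker inhibitor of growth), the three measured compounds stand as follows. Compound 1 `CCC1C(=O)N(C)c2cnc(Nc3ccc(S(=O)(=O)NCC(C)C)cc3)nc2N1c1ccn(C)n1` gives 15000 nM. Compound 2 `CCCNS(=O)(=O)c1ccc(Nc2ncc3c(n2)N(c2ccn(C)n2)C(CC)C(=O)N3C)cc1` gives 21700 nM. Compound 3 `CCCNC(=O)c1ccc2c(ccn2-c2ncc3c(n2)N(c2ccn(C)n2)C(CC)C(=O)N3C)c1` gives 11000 nM.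

Compound 2 and compound 1 share a core and differ by methyl in place of hydrogen on a saturated chain carbon bound to two saturated chain carbons; this gave a 1.4-fold lower number from compound 2 to compound 1 (0.16 log units; within the scatter). Compound 3 carries a different core, and the difference between the two cores is not broken down here. Compound 4 `CCCCNC(=O)c1ccc2c(ccn2-c2ncc3c(n2)N(c2ccn(C)n2)C(CC)C(=O)N3C)c1` is made from compound 3 by methyl in place of hydrogen on a saturated chain carbon, three bonds along the chain from an amide-type nitrogen, the same kind of change, though here the place is three bonds along the chain from an amide-type nitrogen rather than a carbon bound to two saturated chain carbons. Because a 1.4-fold lower number from compound 2 to compound 1 (0.16 log units; within the scatter) stayed within the scatter, a step of similar size, a 1.2-fold lower number from compound 3 to compound 4 (0.09 log units; within the scatter), is expected for compound 4. Compound 4 is therefore estimated at 9000 nM, with a range from 4000 nM to 25000 nM.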

Compound 4, concentration for 50% growth inhibition: 12000 nM
For compound 4 the middle estimate is 1.3-fold (0.12 log units) below the measured one; measured number inside the range.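

In this assay the added methyl gave a result that reads alike on the two cores (a 1.1-fold higher number from compound 3 to compound 4 (0.04 log units; within the scatter)), and the comparison with the earlier step bears this out: the same change on two cores in this assay, a 1.4-fold lower number (0.16 log units; within the scatter) from compound 2 to compound 1 and a 1.1-fold higher number (0.04 log units; within the scatter) from compound 3 to compound 4, 1.6-fold (0.20 log units) apart, within the scatter of two such steps. Within the data shown here, this shows only that the change left the number within the scatter on both cores, and the two steps agree only in that sense. It does not show that an effect of measurable size carries from one core to the other, and the methyl also sits at a different place in each pair.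

The compounds shown leave open whether a chain longer than butyl, an amine or a carboxylic acid on the amide side chain of compound 4 would move the number beyond the scatter.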